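A few compounds are considered here, and "the series" means these few. Any claim that something is new, unique, unknown or untested is made for them only; others in the source may bear on it.

Of the compounds shown here, three built on one shared core have been tested in an ADME assay on Vero cells (Chlorocebus sabaeus) for cytotoxicity, read by MTT assay, with a stated time of 48 h; a higher number here means a weaker inhibitor, a lower number a stronger inhibitor. Compound 1 `O=C(OC1CCC(CN2CCN(c3cc(=O)c4cc(C(F)(F)F)cc([N+](=O)[O-])c4s3)CC2)CC1)c1cccc(C(F)(F)F)c1` carries a 3-(trifluoromethyl)phenyl group on its carbonyl carbon, and in this assay compound 1 gives > 64 ug/mL, which is a limit of the assay and not a number. Compound 2 `Cc1ccc(C(=O)OC2CCC(CN3CCN(c4cc(=O)c5cc(C(F)(F)F)cc([N+](=O)[O-])c5s4)CC3)CC2)cc1` carries 4-methylphenyl in its place, and in this assay compound 2 likewise gives only a limit, > 64 ug/mL. Compound 3 `O=c1cc(N2CCN(CC3CCC(OS(=O)(=O)c4ccc5ccccc5c4)CC3)CC2)sc2c([N+](=O)[O-])cc(C(F)(F)F)cc12`, a differently linked analogue, also gives a limit in this assay, > 64 ug/mL. Because all three sit at the limit of > 64 ug/mL in this assay, at which 3 of the 3 values shown sit, compound 2 cannot be placed above or below its neighbours, and the step that the two limits leave unreadable from compound 1 to compound 2 remains unreadable, both of its ends being limits.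

Compound 4 `O=C(OC1CCC(CN2CCN(c3cc(=O)c4cc(C(F)(F)F)cc([N+](=O)[O-])c4s3)CC2)CC1)c1cccs1` changes the group on the carbonyl carbon once more: thiophen-2-yl in place of 4-methylphenyl on a carbonyl carbon. For the measured compounds named here, no measured step can guide this exchange, since the only step at that carbon, a step that the two limits leave unreadable from compound 1 to compound 2, could not be sized. Going by the values given here, with every value so far resting at the limit of > 64 ug/mL in this assay, at which 3 of the 3 values shown sit, the expectation in this assay is no step beyond the scatter, and the estimated step is a step that the limit leaves unreadable from compound 2 to compound 4. Compound 4 is therefore expected at 80 ug/mL, within a range from 40 ug/mL to 160 ug/mL, and will most probably be reported again only as a limit.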

Compound 4, half-maximal inhibitory concentration: > 64 ug/mL
Compound 4 gave a limit, no number (the forecaster's own chance of this, stated with the estimate: 85%); the middle value does not contradict the limit.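

For the compounds shown here, compound 1, compound 2 and compound 4 each give only a limit in this assay and not a number, and no step among them can be read. The compounds shown leave open whether exchanging the group on the carbonyl carbon alters the result in this assay at all.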